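A Second Fluorine on the Aryl Ring of Compound 2

The source may report more compounds than this note shows. Statements on the series, on what has been measured and on what is new or still open speak of the compounds shown alone.

Compound 2 `CC1=C(/C=C/C(=O)/C=C/c2cccc(C(F)(F)F)c2)C(C)(C)CCC1O` gives the lowest of the three numbers in a functional assay on LNCaP cells (Homo sapiens) for cytotoxicity, read by MTT assay, with a stated time of 72 h (on this read-out higher numbers stand for weaker inhibition and lower numbers for stronger inhibition), with 740 nM. Compound 1 `CC1=C(/C=C/C(=O)/C=C/c2ccccc2)C(C)(C)CCC1O` gives 5800 nM, and compound 3 `CC1=C(/C=C/C(=O)/C=C/c2ccc(F)c(C(F)(F)F)c2)C(C)(C)CCC1O` gives 2200 nM. Compound 4 `CC1=C(/C=C/C(=O)/C=C/c2cc(F)cc(C(F)(F)F)c2)C(C)(C)CCC1O` differs from compound 2 by fluoro in place of hydrogen on an aromatic carbon. Among the compounds with values here, two measured steps bear on this change. The step of a 7.8-fold lower number from compound 1 to compound 2 (0.89 log units; beyond the scatter) shows what trifluoromethyl in place of hydrogen did; more directly, the step of a 3.0-fold higher number from compound 2 to compound 3 (0.47 log units; beyond the scatter) shows what a fluoro in place of hydrogen on an aromatic carbon did to compound 2. Because the step of a 3.0-fold higher number from compound 2 to compound 3 (0.47 log units; beyond the scatter) raised the number, a similar modest rise is expected for compound 4, a 2.0-fold higher number from compound 2 to compound 4 (0.31 log units; beyond the scatter). Compound 4 is therefore estimated to give 1500 nM in this assay, with a range from 600 nM to 4000 nM.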

Compound 4, half-maximal inhibitory concentration: 1100 nM
Compound 4: the middle estimate sits 1.4-fold (0.13 log units) above what was measured; the measured number falls inside the stated range.
By their numbers in this assay, from the lowest: compounds 2, 4 and 3 (each within the scatter of the next, the first and the last beyond it); then compound 1.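

With fluoro on an aromatic carbon meta to a trifluoromethyl group, this assay gives a 1.5-fold higher number from compound 2 to compound 4 (0.17 log units; within the scatter), so this position tolerates the change without a shift that can be told from the scatter. The fluoro of compound 3 had instead given a 3.0-fold higher number from compound 2 to compound 3 (0.47 log units; beyond the scatter), which shows that the outcome of this same change on the aryl ring of compound 2 depends on where the fluoro sits. Nothing available explains this difference between the two positions. The compounds shown leave open whether a group larger than fluoro, such as chloro, methoxy or an amine, would be tolerated on this carbon. They also leave open whether a nitrile in place of the trifluoromethyl group would keep the number of compound 2.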